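The source may hold more compounds than are shown below. What is called first, only, known or untested is meant among the compounds shown, and "the series" means these compounds.

In a functional assay on MCF7 cells (Homo sapiens) for antiproliferative activity, with a stated time of 96 h (a lower number here means a stronger inhibitor, a higher number a weaker inhibitor), the measured compounds read:
Compound 1 `Cc1cc(=O)oc2cc(OCC(=O)c3ccc(C(C)(C)C)cc3)ccc12`: 20700 nM
Compound 2 `Cc1cc(=O)oc2cc(OCC(=O)c3ccc(F)cc3)ccc12`: > 100000 nM, a limit of the assay
Compound 3 `Cc1cc(=O)oc2cc(OCC(=O)c3ccc(OC(F)(F)F)cc3)ccc12`: > 100000 nM, a limit of the assay

Compound 1 alone has a number, the others sitting at the limit of > 100000 nM in this assay, at which 2 of the 3 values shown sit. Compound 4 `CC(C)(C)c1ccc(C(=O)COc2ccc3c(C(F)(F)F)cc(=O)oc3c2)cc1` keeps the tert-butyl of compound 1 and changes the shared core: trifluoromethyl in place of methyl on an aromatic carbon.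

Neither measured step touches that place. Both change the tert-butyl instead: fluoro gives an at least 4.8-fold higher number from compound 1 to compound 2 (0.68 log units; beyond the scatter), and trifluoromethoxy gives an at least 4.8-fold higher number from compound 1 to compound 3 (0.68 log units; beyond the scatter). With the tert-butyl retained, no step beyond the scatter is expected in this assay, in either direction. The estimated change is a 1.0-fold lower number from compound 1 to compound 4 (0.01 log units; within the scatter). For compound 4 the expected value is 20000 nM, with an estimated range from 6000 nM to 70000 nM.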

Compound 4, half-maximal inhibitory concentration: "not active" (no number reported)
Compound 4 has no reported number here; the estimate stays without a comparison.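

For the compounds shown here, compound 4 is reported only as "not active", without a number, and no step from compound 1 can be read. The compounds shown leave open how far trifluoromethyl in place of methyl moves the number.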